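Swapping methyl for chloro on a quaternary-ammonium amide

The source may report more compounds than this note shows. Statements on the series, on what has been measured and on what is new or still open speak of the compounds shown alone.

Two measured compounds share the same core and differ in their tail and in one group on an aromatic ring. In an assay on LX2 cells for inhibition of COL1A1 promoter (Homo sapiens), read by a luciferase reporter, with a stated time of 24 h, tested at 50 uM (on this read-out higher numbers stand for a stronger effect at the one concentration tested and lower numbers for a weaker effect), compound 1 `CC[N+]1(CCCCCCCOc2ccc(-n3cc(C(=O)Nc4cc(F)cc(F)c4)c(=O)c4ccc(N(C)C)nc43)cc2Cl)CCCCC1` gives 50.4%, while compound 2 `Cc1cc(-n2cc(C(=O)Nc3cc(F)cc(F)c3)c(=O)c3ccc(N(C)C)nc32)ccc1OCCCCCCC[N+]1(C)CCN(C)CC1` gives 32%, the lower of the two numbers and a gap beyond the usual scatter. Compound 3 `CN1CC[N+](C)(CCCCCCCOc2ccc(-n3cc(C(=O)Nc4cc(F)cc(F)c4)c(=O)c4ccc(N(C)C)nc43)cc2Cl)CC1` is compound 2 with one change: chloro in place of methyl on an aromatic carbon. Going by the values given here, no measured pair isolates this change, so only a small step is expected, if any, in either direction. Compound 3 is estimated at 38%, between 20% and 56%, an expected step of a number 6 percentage points higher from compound 2 to compound 3 (within the scatter).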

Compound 3, a percentage reported as inhibition, at one concentration (the size of the read-out at that concentration, not a potency): 15.4%
Compound 3: the middle estimate sits 22.6 percentage points above what was measured; the whole stated range lies above it.
By their numbers in this assay, from the lowest: compound 3; then compound 2; then compound 1.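

At this aromatic carbon the swap is not neutral: in this assay, chloro in place of methyl gives a number 16.6 percentage points lower from compound 2 to compound 3 (beyond the scatter). With chloro kept, changing only the six-membered ring at the end of the chain, from one hetero atom to two, gives a number 35 percentage points lower from compound 1 to compound 3 (beyond the scatter), a large step. The data shown offer no explanation for either step. Going by these compounds, it remains open how a fluoro or methoxy group on this same aromatic carbon would compare, and whether swapping chloro for methyl does the same with the ring of compound 1.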